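The source may report more compounds than this note shows. Statements on the series, on what has been measured and on what is new or still open speak of the compounds shown alone.

Compound 1 `COc1ccccc1CNc1ccc(C2CCCCC2)cc1`: in a functional assay on Jurkat cells (Homo sapiens) for activation, with a stated time of 24 h (on this read-out higher numbers stand for an effect only at larger amounts of compound and lower numbers for an effect already at smaller amounts), compound 1 is reported as "not active" (no number reported), no number.
Compound 2 `Cc1ccc(-c2ccc(NCc3ccccc3O)cc2)cc1`: in this assay compound 2 gives 3790 nM.
Compound 3 `N#Cc1ccc(-c2ccc(NCc3ccccc3O)cc2)cc1`: in this assay compound 3 is reported as "not active" (no number reported), no number.

Compound 3 therefore stands without a single number in this assay, and compound 1 is a further entry without one; only compound 2 carries a measured value. Compound 4 `CCSc1ccc(-c2ccc(NCc3ccccc3O)cc2)cc1` differs from compound 3 by ethylsulfanyl in place of cyano on an aromatic carbon. Among the compounds with values here, no step between measured compounds is recorded, so the size of the change is open; the one numbered neighbour, compound 2, suggests that compound 4 may return a number rather than none, with the step from compound 3 taken as a gain. For compound 4 a half-maximal effective concentration of about 5000 nM is expected, estimated between 1500 nM and 20000 nM.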

Compound 4, half-maximal effective concentration: 1980 nM
The estimate for compound 4 lay 2.5-fold (0.40 log units) above the measured number, within the range that was stated.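

With ethylsulfanyl at this position, para to a large group, compound 4 gives a number in this assay, whereas compound 3 with cyano gives none. Ethylsulfanyl in place of methyl shows a 1.9-fold lower number from compound 2 to compound 4 (0.28 log units; within the scatter), so these two groups cannot be told apart here and the position holds more than one group that gives a number. No measurement shown accounts for the difference from cyano. On these data alone, whether an amine, a carboxylic acid or a longer chain at this position would also give a number remains open.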